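This account rests on a few compounds, and the source may have more. Where it says the series, first, only, none or still open, it means among the compounds named here.

Measured so far in a functional assay on HT-29 cells (Homo sapiens) for inhibition, read by MTT assay, with a stated time of 48 h; a lower number here means a stronger inhibitor, a higher number a weaker inhibitor:

- compound 1 `Cc1ccc(NC(=S)NC(=O)c2ccc(OCc3ccc(Cl)cc3Cl)cc2)cc1-c1nc2ccccc2[nH]1`: 11600 nM
- compound 2 `Cc1ccc(NC(=S)NC(=O)c2ccc(OCc3ccc(F)cc3)cc2)cc1-c1nc2ccccc2[nH]1`: 1910 nM
- compound 3 `Cc1ccc(NC(=O)NC(=O)c2ccc(OCc3cccc(Cl)c3)cc2)cc1-c1nc2ccccc2[nH]1`: 15400 nM

Compound 3 gives the highest of the three numbers in this assay. Its number and that of compound 1 lie within the scatter of each other, so no order between them is claimed; the number of compound 2 sits clearly lower than that of compound 3.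

Compound 4 `Cc1ccc(NC(=O)NC(=O)c2ccc(OCc3cccc(Cl)c3Cl)cc2)cc1-c1nc2ccccc2[nH]1` has not been measured. It differs from compound 3 by chloro in place of hydrogen on an aromatic carbon, on an aromatic carbon of a six-membered aromatic ring of carbon only, ortho to a chloro group and ortho to a large group; read one bond further out, 3-chlorobenzyl becomes 2,3-dichlorobenzyl.

Going by the values given here, the only measured step in this assay is a 6.1-fold lower number from compound 1 to compound 2 (0.78 log units; beyond the scatter). It concerns the same benzyl ring, and in that step the loss of two chlorines, with a fluorine entering, went with a lower number. Among the compounds with values here, it is not the same change as here, and compound 1 and compound 3 differ in more than one place, so no step between them is available. Adding a chloro is therefore expected to give, if anything, a somewhat higher number, with the step of a 1.2-fold higher number from compound 3 to compound 4 (0.07 log units; within the scatter) not confidently beyond the scatter.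

Compound 4 is thus estimated at 18000 nM in this assay, expected to fall between 7000 nM and 45000 nM.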

Compound 4, half-maximal inhibitory concentration: 48500 nM
Beside the measured number, compound 4's estimate is 2.7-fold (0.43 log units) below it; measured number above the stated range.
By their numbers in this assay, from the lowest: compound 2; then compounds 1 and 3 (each within the scatter of the next); then compound 4.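

In this assay, going by these compounds alone, chloro in place of hydrogen on an aromatic carbon, ortho to a chloro group and ortho to a large group, gives a 3.1-fold higher number from compound 3 to compound 4 (0.50 log units; beyond the scatter): the first step on this benzyl ring that isolates one added chloro, and a move from 3-chlorobenzyl to 2,3-dichlorobenzyl that is not tolerated without a cost. With a 6.1-fold lower number from compound 1 to compound 2 (0.78 log units; beyond the scatter), both measured steps on this ring now place the higher number on the side carrying more chlorine, and neither goes against this, though two steps make only a thin pattern. Nothing on hand speaks to the origin of the rise at this place.

Whether the rise is specific to chloro remains open, as fluoro, methoxy or an amine on the same aromatic carbon does not appear among the compounds shown. Also open, as far as these compounds go, is whether the same chloro step holds in the thiocarbonyl series of compound 1 and compound 2.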